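Carbamate to Dichlorobenzamide on a Naphthyl Carbinol Core

This account rests on a few compounds, and the source may have more. Where it says the series, first, only, none or still open, it means among the compounds named here.

Of the compounds shown here, three sharing one core have been measured in an assay on LtK cells with ATP-sensitive inward rectifier potassium channel 11 (Homo sapiens) as the target; a lower number here means that less compound is needed, a higher number that more compound is needed for the effect. Compound 1 `COCC(=O)Nc1c(C(O)(C(F)(F)F)C(F)(F)F)ccc2ccccc12` gives 213 nM, compound 2 `CC(C)OC(=O)Nc1c(C(O)(C(F)(F)F)C(F)(F)F)ccc2ccccc12` gives 1160 nM, and compound 3 `O=C(Nc1c(C(O)(C(F)(F)F)C(F)(F)F)ccc2ccccc12)c1ccc(C(F)(F)F)cc1` gives 160 nM. Compound 2 therefore stands with the highest number of the three: a 5.4-fold higher number from compound 1 to compound 2 (0.74 log units; beyond the scatter), and a 7.3-fold lower number from compound 2 to compound 3 (0.86 log units; beyond the scatter). Compound 1 and compound 3 sit close together, since a 1.3-fold lower number from compound 1 to compound 3 (0.12 log units; within the scatter).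

The next compound, compound 4 `O=C(Nc1c(C(O)(C(F)(F)F)C(F)(F)F)ccc2ccccc12)c1cc(Cl)cc(Cl)c1`, differs from compound 2 in one place: 3,5-dichlorophenyl in place of isopropoxy on a carbonyl carbon. Among the measured compounds shown here, the measured step that bears most directly on this change is the one from compound 2 to compound 3, where an aromatic ring likewise replaced isopropoxy on the carbonyl carbon and the number fell clearly, a 7.3-fold lower number from compound 2 to compound 3 (0.86 log units; beyond the scatter). The step from compound 1 to compound 3 shows that exchanging methoxymethyl for an aromatic ring left the number essentially unchanged, so the gain seems tied to leaving isopropoxy rather than to the particular ring. On this basis compound 4 is expected to show a clear downward step in this assay, a 5.8-fold lower number from compound 2 to compound 4 (0.76 log units; beyond the scatter). Compound 4 is accordingly estimated at 200 nM, with a likely range from 80 nM to 500 nM.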

Compound 4, half-maximal effective concentration: 306 nM
Compound 4: middle estimate off by 1.5-fold (0.18 log units), on the low side; the measured number falls inside the stated range.
By their numbers in this assay, from the lowest: compounds 3, 1 and 4 (each within the scatter of the next); then compound 2.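

In this assay a second aromatic ring on the carbonyl carbon also gives a lower number than isopropoxy, a 3.8-fold lower number from compound 2 to compound 4 (0.58 log units; beyond the scatter), so the drop seen with 4-(trifluoromethyl)phenyl is not confined to that one ring, although the non-aromatic methoxymethyl of compound 1 also lies clearly under compound 2. The remaining comparisons separate nothing: there is a 1.9-fold higher number from compound 3 to compound 4 (0.28 log units; within the scatter), and there is a 1.4-fold higher number from compound 1 to compound 4 (0.16 log units; within the scatter), so the two rings and methoxymethyl cannot be put in any order, and of the four groups on this carbonyl carbon only isopropoxy stands apart. Nothing available here explains why isopropoxy differs from the other three groups.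

The compounds shown leave open whether a smaller alkoxy such as methoxy, or an amine such as dimethylamino, on the same carbonyl carbon would group with isopropoxy or with the other three. They also leave open whether an unsubstituted phenyl would match the two substituted rings, which would show whether the chlorine atoms and the trifluoromethyl group matter at this position at all.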